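The compounds below may be only part of what the source reports. "The series", "measured", "known", "first", "only" and "open" are said of these compounds alone.

Measured in a functional assay on A549 cells (Homo sapiens) for antiproliferative activity, read by MTT assay, with a stated time of 72 h; a higher number here means a weaker inhibitor, a lower number a stronger inhibitor:
compound 1, `COc1cc(-n2cnc3ccc(-c4ccc(C(C)=O)cc4)cc32)cc(OC)c1OC` — 2510 nM
compound 2, `COc1cc(-n2cnc3ccc(-c4ccc(C)cc4F)cc32)cc(OC)c1OC` — only a limit of the assay, > 10000 nM
compound 3, `COc1cc(-n2cnc3ccc(-c4ccc([N+](=O)[O-])cc4)cc32)cc(OC)c1OC` — 8940 nM

Compound 1 holds the lowest of the two numbers given in this assay; the nearest is compound 3, reached by a 3.6-fold higher number from compound 1 to compound 3 (0.55 log units; beyond the scatter). Compound 2 sits at the limit of > 10000 nM in this assay, at which 1 of the 3 values shown sits, so its step from compound 1 is an at least 3.9-fold higher number from compound 1 to compound 2 (0.60 log units; beyond the scatter). Between compound 2 and compound 3 the step is an at least 1.1-fold lower number from compound 2 to compound 3 (0.04 log units; that floor lies within the scatter).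

Compound 4, `COc1cc(-n2cnc3ccc(-c4cccc([N+](=O)[O-])c4)cc32)cc(OC)c1OC`, is not yet measured in this assay. Against compound 1 the change is 3-nitrophenyl in place of 4-acetylphenyl on an aromatic carbon. For the measured compounds named here, the one measured step that bears on it is a 3.6-fold higher number from compound 1 to compound 3 (0.55 log units; beyond the scatter), where nitro replaced acetyl; in compound 4 the nitro group belongs to 3-nitrophenyl rather than 4-nitrophenyl, and no measured pair covers that difference. The expected outcome is a step of about the size seen in compound 3, toward a higher number: a 3.2-fold higher number from compound 1 to compound 4 (0.50 log units; beyond the scatter). Compound 4 is therefore estimated at 8000 nM, with a range of 3000 nM to 20000 nM.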

Compound 4, half-maximal inhibitory concentration: 5410 nM
The estimate for compound 4 lay 1.5-fold (0.17 log units) above the measured number; measured number inside the range.
By their numbers in this assay, from the lowest: compound 1; then compounds 4 and 3 (each within the scatter of the next). At a limit, above all of these: compound 2.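

In this assay, the step for 3-nitrophenyl in place of 4-nitrophenyl is a 1.7-fold lower number from compound 3 to compound 4 (0.22 log units; within the scatter), so the nitro group's placement makes no readable difference. The cost of leaving 4-acetylphenyl holds for the nitro group in either placement, and with 3-nitrophenyl it is still beyond the scatter: a 2.2-fold higher number from compound 1 to compound 4 (0.33 log units; beyond the scatter). Compound 2 stands only at a limit of the assay: the limit of > 10000 nM in this assay, at which 1 of the 4 values shown sits. Its step can therefore be given only as a floor: an at least 1.8-fold lower number from compound 2 to compound 4 (0.26 log units; that floor lies within the scatter).

Compound 1 remains the lowest of the series at 2510 nM, yet only acetyl and nitro are compared as named substituents on this ring here, so the reason for its lead stays unknown. From the compounds shown here alone, whether an amine, a carboxylic acid or a longer chain in place of acetyl would go lower remains open.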